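From 4-hydroxyphenyl to 2,4-difluorophenyl in a growth-inhibition series

This account rests on a few compounds, and the source may have more. Where it says the series, first, only, none or still open, it means among the compounds named here.

For the measured compounds named here, in a functional assay on PC-3 cells (Homo sapiens) (on this read-out lower numbers stand for stronger inhibition of growth and higher numbers for weaker inhibition of growth), compound 3 `O=S(=O)(/C=C/c1ccc(O)cc1)Cc1ccc(Nc2ncnc3ccc(Br)cc23)cc1` gives 42000 nM, the higher of the two exact numbers so far. Compound 2 `O=S(=O)(/C=C/c1ccc(Cl)c(Cl)c1)Cc1ccc(Nc2ncnc3ccc(Br)cc23)cc1` gives 11000 nM. Compound 4 `O=S(=O)(/C=C/c1ccc(F)cc1F)Cc1ccc(Nc2ncnc3ccc(Br)cc23)cc1` differs from compound 3 in one group, with 2,4-difluorophenyl in place of 4-hydroxyphenyl on a double-bonded chain carbon bound to a double-bonded chain carbon.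

One measured step involves the same departing group. Putting 4-hydroxyphenyl in place of 3,4-dichlorophenyl gave a 3.8-fold higher number from compound 2 to compound 3 (0.58 log units; beyond the scatter), a modest change beyond the scatter. Compound 1 `O=S(=O)(/C=C/c1ccc(F)cc1F)Cc1ccc(Nc2ncnc3ccccc23)cc1` also carries 2,4-difluorophenyl, but on a different core, and its reading of > 100000 nM is a limit of the assay and not a number.

Removing 4-hydroxyphenyl from compound 3 is therefore expected to move the number modestly lower, though a different halogenated ring takes its place here. The expected change is a 1.9-fold lower number from compound 3 to compound 4 (0.28 log units; within the scatter). For compound 4 the estimate is 22000 nM, with an expected range of 7000 nM to 70000 nM.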

Compound 4, concentration for 50% growth inhibition: 100000 nM
For compound 4 the middle estimate is 4.5-fold (0.66 log units) below the measured one; the measured number lies above the stated range.
By their numbers in this assay, from the lowest: compound 2; then compound 3; then compound 4.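

In this assay, 2,4-difluorophenyl on a double-bonded chain carbon gives weaker growth inhibition than either of the other two rings on the shared core, with a 2.4-fold higher number from compound 3 to compound 4 (0.38 log units; beyond the scatter) and a 9.1-fold higher number from compound 2 to compound 4 (0.96 log units; beyond the scatter). For the compounds shown here, the earlier compounds showed only one halogenated ring ahead of 4-hydroxyphenyl, but compound 3 now sits between two halogenated rings, so among compound 2, compound 3 and compound 4 a halogenated ring does not by itself give the lower number. Compound 1 reads as a limit of the assay, so bromo in place of hydrogen on an aromatic carbon gives a number no higher from compound 1 to compound 4 (the limit leaves the size open), a step whose size cannot be read: the limit of > 100000 nM in this assay, at which 1 of the 4 values shown sits.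

Compound 2 and compound 4 differ both in the halogen and in where it sits on the ring, so these two changes remain unseparated. On these data alone, how a phenyl ring carrying an amine or a carboxylic acid would read at this place also stays open.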